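The compounds below may be only part of what the source reports. "The series", "measured", "known", "first", "only" and "open" are said of these compounds alone.

Compounds measured in a functional assay on ECV-304 cells (Homo sapiens) for cytotoxicity; on this read-out lower numbers stand for stronger inhibition and higher numbers for weaker inhibition:
Compound 1, `O=S(=O)(NN1C(=S)S/C(=C\c2ccc(Cl)c(Cl)c2)C1O)c1ccc(Cl)cc1`, gives > 50000 nM, which is a limit of the assay and not a number.
Compound 2, `O=C1/C(=C/c2ccccc2F)SC(=S)N1NS(=O)(=O)c1ccccc1`, gives > 50000 nM, which is likewise a limit of the assay and not a number.

Compound 2 therefore stands nowhere in particular among the values shown: both readings are limits, as the limit of > 50000 nM in this assay, at which 2 of the 2 values shown sit, states, and no order between compound 1 and compound 2 can be drawn. Among the measured compounds shown here, no step between measured compounds that differ in one place exists here, so nothing about the size of any change can be read off.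

Compound 3, `Cc1ccc(/C=C2\SC(=S)N(NS(=O)(=O)c3ccccc3)C2=O)cc1C`, has not yet been measured. It differs from compound 2 by 3,4-dimethylphenyl in place of 2-fluorophenyl on a double-bonded chain carbon bound to a double-bonded ring carbon. The expected step that the limit leaves unreadable from compound 2 to compound 3 is none beyond the scatter, since both measured compounds sit at the limit and the data give no lead toward a gain. Compound 3 is estimated at 60000 nM, within 15000 nM to 250000 nM, most likely reported again as a limit.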

Compound 3, half-maximal inhibitory concentration: > 50000 nM
Compound 3: no number, only a limit (the forecaster's own chance of this, stated with the estimate: 75%); the middle value is on the limit's open side.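

Among the compounds shown here, no step from compound 2 to compound 3 can be read, because both readings are limits of the assay and not numbers: the limit of > 50000 nM in this assay, at which 3 of the 3 values shown sit.

The compounds shown leave open whether compound 1, compound 2 and compound 3 differ at all, and which change in the group on the double-bonded chain carbon, if any, would give a measurable value.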